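The source may report more compounds than this note shows. Statements on the series, on what has been measured and on what is new or still open speak of the compounds shown alone.

Two compounds of a shared core carry long chains at the same position. Compound 1 `CC/C=C\C/C=C\C/C=C\CCCCCCCc1cc(=O)c2c(O)c(C)c(O)c(C)c2o1` gives 17500 nM in a functional assay on MCF7 cells (Homo sapiens) for antiproliferative activity, read by MTT assay; a higher number here means a weaker inhibitor, a lower number a stronger inhibitor. Compound 2 `CCCCCCCCCCCCCCCc1cc(=O)c2c(O)c(C)c(O)cc2o1`, measured in this assay, gives 43200 nM, the highest of the two numbers, with compound 1 the nearer of them. Compound 3 `CCCCCCCCCCCCCCCc1cc(=O)c2c(O)c(C)c(O)c(C)c2o1` differs from compound 2 only by methyl in place of hydrogen on an aromatic carbon. Among the compounds with values here, no measured pair shows this change alone, so the step is uncertain. The expected step is a small move toward a stronger inhibitor of roughly a 1.7-fold lower number from compound 2 to compound 3 (0.24 log units; within the scatter). For compound 3 the expected result is 25000 nM, within 10000 nM to 60000 nM.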

Compound 3, half-maximal inhibitory concentration: > 67200 nM
Compound 3: a limit, no number; the forecaster's own chance of this, stated with the estimate: 5%; middle value at least 2.6-fold (0.42 log units) away from the limit.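

Compound 3 gives only a limit of the assay, > 67200 nM, not a number. Methyl in place of hydrogen on this aromatic carbon therefore brings no sign of a stronger inhibitor, with an at least 1.5-fold higher number from compound 2 to compound 3 (0.19 log units; that floor lies within the scatter). A change in the chain alone, seven bonds along it from an aromatic carbon, gives an at least 3.8-fold higher number from compound 1 to compound 3 (0.58 log units; beyond the scatter), so the outer part of the chain does affect the result on this methylated core. From the compounds shown here alone, the true size of both steps stays open. So does whether an amine at this aromatic carbon, or a shorter chain, would give a lower number.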